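The source may hold more compounds than are shown below. What is called first, only, known or untested is meant among the compounds shown, and "the series" means these compounds.

Measured compounds:
Compound 1 `CS(=O)(=O)c1ccc(F)cc1NCC1=NCCN1` gives < 100000 nM
Compound 2 `CSc1ccc(F)cc1NCC1=NCCN1` gives 1.86 nM

In a functional assay for agonist activity at Alpha-1B adrenergic receptor (Homo sapiens) (on this read-out higher numbers stand for an effect only at larger amounts of compound and lower numbers for an effect already at smaller amounts), compound 1 gives only a limit, < 100000 nM. In this assay compound 2 gives 1.86 nM, the only full number among the two results shown. The step that the limit leaves unreadable from compound 1 to compound 2 cannot be sized. Compound 1 sits at a limit (the limit of < 100000 nM in this assay, at which 1 of the 2 values shown sits).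

Compound 3 `CSc1ccc(C(F)(F)F)cc1NCC1=NCCN1` differs from compound 2 by trifluoromethyl in place of fluoro on an aromatic carbon. Among the compounds with values here, no measured step concerns this change: the one recorded step, methylsulfanyl in place of methylsulfonyl, is unreadable and touches a different group of the shared core. With nothing measured to lean on, the expectation for compound 3 is a step of a 2.7-fold higher number from compound 2 to compound 3 (0.43 log units; beyond the scatter), a modest weakening that stays close to the scatter. Compound 3 is therefore estimated at 5 nM, with a likely range from 1.5 nM to 25 nM.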

Compound 3, half-maximal effective concentration: 6.03 nM
Estimate against measurement, compound 3: 1.2-fold (0.08 log units) below, and the stated range covers the measured number.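

Replacing fluoro with trifluoromethyl on the aromatic carbon para to a methylsulfanyl group gives a 3.2-fold higher number from compound 2 to compound 3 (0.51 log units; beyond the scatter) in this assay and is the first step among these compounds whose size can be read, since the earlier step cannot be read. The position therefore takes a group of 4 heavy atoms in place of 1 heavy atom, and compound 3 still gives a full number of 6.03 nM in this assay rather than a limit. Nothing measured here accounts for the size of this step.

From the compounds shown here alone, how an amine, a nitrile or a methoxy group would behave at this position remains open. Going by these compounds, it is also open whether the same swap would give a similar step if the methylsulfanyl group were replaced by a longer chain such as ethylsulfanyl.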